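The source may report more compounds than this note shows. Statements on the series, on what has been measured and on what is new or still open speak of the compounds shown alone.

Values in a physicochemical assay for lipophilicity, read by HPLC, at pH 7.4 (on this read-out higher numbers stand for higher lipophilicity and lower numbers for lower lipophilicity), so far:
Compound 1 (`CS(=O)(=O)c1ccc(-c2cnc(N)c(-c3ccc(C#N)cc3)c2)cc1`) reads 2.4
Compound 2 (`CS(=O)(=O)c1ccc(-c2cnc(N)c(-c3ccc(S(C)(=O)=O)cc3)c2)cc1`) reads 2
Compound 3 (`Cc1ccc(-c2cc(-c3ccc(S(C)(=O)=O)cc3)cnc2N)c2cccnc12`) reads 2.6

Compound 2 is the lowest of the three in this assay and lies beyond the scatter from both others. Compound 4 (`CS(=O)(=O)c1ccc(-c2cnc(N)c(-c3ccc(C(N)=O)cc3)c2)cc1`) has carbamoyl in place of methylsulfonyl on an aromatic carbon, para to a large group (carbamoyl in place of methylsulfonyl on an aromatic carbon). Going by the values given here, one measured step bears on this place, the modest a number 0.40 log units lower from compound 1 to compound 2 (beyond the scatter) (methylsulfonyl in place of cyano on an aromatic carbon). Among the compounds with values here, no measured compound carries carbamoyl, and the data give no direction for it. A small change is therefore expected, and the estimated step is a number 0.10 log units lower from compound 2 to compound 4 (within the scatter) and stays within the scatter. For compound 4 the expected value is 1.9 within a range from 1.5 to 2.3 as estimated here.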

Compound 4, distribution coefficient: 1.5
Compound 4: the middle estimate sits 0.40 log units above what was measured; measured number inside the range.
By their numbers in this assay, from the lowest: compound 4; then compound 2; then compounds 1 and 3 (each within the scatter of the next).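

In this assay, carbamoyl on this aromatic carbon, para to a large group, proves no neutral replacement for methylsulfonyl, giving a number 0.50 log units lower from compound 2 to compound 4 (beyond the scatter). Set against cyano, the same group gives a number 0.90 log units lower from compound 1 to compound 4 (beyond the scatter). The three groups at this place now fall in a clear order, with carbamoyl below methylsulfonyl and methylsulfonyl below cyano, each step beyond the scatter.

Nothing given here accounts for the size of these steps. On these data alone, how a carboxylic acid or an amine at this place would read remains open, as does whether the carbamoyl step would carry over to the core of compound 3.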